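The compounds below may be only part of what the source reports. "The series", "measured", "known", "first", "only" and "open" are said of these compounds alone.

Measured compounds:
compound 2 `O=C1CSC(c2ccccc2)N1n1c(CSc2nnc(-c3ccncc3)o2)nc2ccc(Br)cc2c1=O`: 31.3%
compound 1 `COc1ccc(C2SCC(=O)N2n2c(CSc3nnc(-c4ccncc4)o3)nc3ccc(Br)cc3c2=O)cc1`: 35.3%

Among the measured compounds shown here, in a functional assay on the whole organism (strain Charles-Foster albino) for inhibition, with Rattus norvegicus as the target, read by paw edema, at a dose of 50 mg/kg by the oral route (a lower number here means less inhibition, a higher number more inhibition at the dose given (going by the name of the read-out)), compound 2 gives 31.3%, the lowest of the two numbers so far; the nearest is compound 1 with 35.3%, and the two lie within the scatter of each other. Compound 3 `O=C1CSC(c2ccc(O)cc2)N1n1c(CSc2nnc(-c3ccncc3)o2)nc2ccc(Br)cc2c1=O` has not yet been measured. It differs from compound 2 by hydroxy in place of hydrogen on an aromatic carbon. For the measured compounds named here, the only measured step that bears on this change is a number 4 percentage points lower from compound 1 to compound 2 (within the scatter), which concerns the same aromatic carbon and shows that methoxy against hydrogen there made no difference beyond the scatter. Going by the values given here, with one such step as the sole guide, no step beyond the scatter is expected in this assay for hydroxy in place of hydrogen either. Compound 3 is therefore expected to give about 34% in this assay, with a range from 22% to 46%. The expected step is a number 2.7 percentage points higher from compound 2 to compound 3 (within the scatter), within the scatter.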

Compound 3, a percentage reported as inhibition, in the whole organism at one dose (the size of the read-out at that dose, not a potency): 32.7%
For compound 3 the middle estimate is 1.3 percentage points above the measured one; the range from low to high includes it.
By their numbers in this assay, from the lowest: compounds 2, 3 and 1 (each within the scatter of the next).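

Among the compounds shown here, on the aromatic carbon para to a large group, the change from phenyl to 4-hydroxyphenyl gives in this assay a number 1.4 percentage points higher from compound 2 to compound 3 (within the scatter), so hydroxy joins hydrogen and methoxy as a third group at this position, and no pair of the three is separated beyond the scatter. Loss of the methyl from the oxygen on the aromatic ring gives a number 2.6 percentage points lower from compound 1 to compound 3 (within the scatter), which shows that the free hydroxy, with its hydrogen-bond donor, and the methoxy cannot be told apart in this read-out at this dose. No measurement is available that could explain these results.

The compounds shown leave open whether an amine, a carboxylic acid or a longer alkoxy chain at this carbon would give a step beyond the scatter. They also leave open whether hydroxy would read the same on another carbon of this ring.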